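The source may report more compounds than this note shows. Statements on the series, on what has been measured and on what is new or still open speak of the compounds shown alone.

Measured in a functional assay on DU-145 cells (Homo sapiens) for cytotoxicity, read by trypan blue exclusion, with a stated time of 96 h; a higher number here means a weaker inhibitor, a lower number a stronger inhibitor:
- compound 1 `COC(=O)C(C)(C)Nc1cc(CS(=O)(=O)/C=C/c2c(OC)cc(OC)cc2OC)ccc1OC`: 2500 nM
- compound 2 `COC(=O)C(Nc1cc(CS(=O)(=O)/C=C/c2c(OC)cc(OC)cc2OC)ccc1OC)c1ccc(Br)cc1`: 300 nM
- compound 3 `COc1cc(OC)c(/C=C/S(=O)(=O)Cc2ccc(OC)c(N[C@@H](C)C(=O)O)c2)c(OC)c1`: 25 nM

Compound 3 has the lowest number of the three, which makes it the strongest inhibitor so far. The gaps are clear: a 12-fold lower number from compound 2 to compound 3 (1.08 log units; beyond the scatter), and a 100-fold lower number from compound 1 to compound 3 (2.00 log units; beyond the scatter).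

The next compound is compound 4 `COc1cc(OC)c(/C=C/S(=O)(=O)Cc2ccc(OC)c(NC(C(=O)O)c3ccc(F)cc3)c2)c(OC)c1`. It keeps the shared core and changes one group: carboxy(4-fluorophenyl)methyl in place of 1-carboxyethyl on a nitrogen on an aromatic ring. Put simply, carboxy(4-fluorophenyl)methyl stands in place of 1-carboxyethyl on a nitrogen on an aromatic ring.

Going by the values given here, no measured step makes exactly this change, so the evidence is indirect. Among the compounds with values here, two steps bear on it. The first is an 8.3-fold lower number from compound 1 to compound 2 (0.92 log units; beyond the scatter), where a group carrying an aromatic ring replaces one without, and the number falls. The second is a 12-fold lower number from compound 2 to compound 3 (1.08 log units; beyond the scatter), where the number falls further as the group with the ring leaves, but methoxycarbonyl also gives way to carboxy, and the data cannot separate those two changes. Compound 4 has the carboxy of compound 3 and a ring like that of compound 2, so it should land between them.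

The expected change is a 3.6-fold higher number from compound 3 to compound 4 (0.56 log units; beyond the scatter), a modest move towards weaker inhibition. For compound 4 the estimated value is 90 nM, with an expected range from 25 nM to 400 nM.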

Compound 4, half-maximal inhibitory concentration: 150 nM
Compound 4: the middle estimate sits 1.7-fold (0.22 log units) below what was measured, and the stated range covers the measured number.
By their numbers in this assay, from the lowest: compound 3; then compounds 4 and 2 (each within the scatter of the next); then compound 1.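

With the carboxy group held constant, the effect of a ring-bearing group can now be read without the change from methoxycarbonyl to carboxy that clouded the earlier comparison: in this assay there is a 6.0-fold higher number from compound 3 to compound 4 (0.78 log units; beyond the scatter), so carboxy(4-fluorophenyl)methyl gives a weaker result than 1-carboxyethyl on this nitrogen. This runs opposite to the methoxycarbonyl pair, where a group with a ring gave an 8.3-fold lower number from compound 1 to compound 2 (0.92 log units; beyond the scatter), so the ring's apparent benefit did not carry over to the carboxy compounds, although the groups it replaced also differ. Swapping (4-bromophenyl)(methoxycarbonyl)methyl for carboxy(4-fluorophenyl)methyl gives a 2.0-fold lower number from compound 2 to compound 4 (0.30 log units; within the scatter), which leaves those two compounds indistinguishable, while a 17-fold lower number from compound 1 to compound 4 (1.22 log units; beyond the scatter) keeps compound 4 well clear of compound 1.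

The compounds shown leave open whether the loss from compound 3 to compound 4 belongs to the ring, to its fluorine or to the defined stereocentre present only in compound 3, and a plain phenyl or a longer chain such as propyl on the same carbon would help to separate these. No measurement shown here gives a reason for any of these shifts.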